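Aryl-to-alkyl carbamate swap: notes on compound 4

This account rests on a few compounds, and the source may have more. Where it says the series, first, only, none or still open, it means among the compounds named here.

Three compounds carry numbers in a functional assay on HeLa cells (Homo sapiens) for cytotoxicity, read by MTT assay, with a stated time of 3 days; a higher number here means a weaker inhibitor, a lower number a stronger inhibitor. Compound 1 `C[C@H]1O[C@@H](n2cc(F)c(NC(=O)Oc3ccc(Cl)cc3)nc2=O)[C@H](O)[C@@H]1O` gives 30 ug/mL, compound 2 `C[C@H]1O[C@@H](n2cc(F)c(NC(=O)Oc3ccc([N+](=O)[O-])cc3)nc2=O)[C@@H]2OC(=O)O[C@@H]21` gives 30 ug/mL, and compound 3 `C[C@H]1O[C@@H](n2cc(F)c(NC(=O)Oc3ccc([N+](=O)[O-])cc3)nc2=O)[C@H](O)[C@@H]1O` gives 10 ug/mL. Compound 2 sits level with compound 1 at the digits shown, the two together being the highest numbers of the set; compound 3 lies furthest from it, with a 3.0-fold lower number from compound 2 to compound 3 (0.48 log units; beyond the scatter).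

Compound 4 `CC(C)CCOC(=O)Nc1nc(=O)n([C@@H]2O[C@H](C)[C@H]3OC(=O)O[C@H]32)cc1F` is not yet measured. Relative to compound 2 the change is isopentyl in place of 4-nitrophenyl on an oxygen next to a carbonyl group. The carbamate ester end has been varied once before, in a 3.0-fold lower number from compound 1 to compound 3 (0.48 log units; beyond the scatter), a modest step in this assay. The other recorded step, a 3.0-fold lower number from compound 2 to compound 3 (0.48 log units; beyond the scatter), concerns the sugar part and does not touch the carbamate. Nothing measured here replaces an aromatic ester group with an open chain, so the bearing of the known steps is indirect: they only show that changes around the carbamate ester move the number by modest amounts in either direction.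

For compound 4 a step of about a 1.3-fold higher number from compound 2 to compound 4 (0.12 log units; within the scatter) is therefore expected, with no firm direction. Compound 4 is estimated at 40 ug/mL, within a range from 12 ug/mL to 120 ug/mL.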

Compound 4, half-maximal inhibitory concentration: 130 ug/mL
Beside the measured number, compound 4's estimate is 3.3-fold (0.51 log units) below it; measured number outside the range, above it.
By their numbers in this assay, from the lowest: compound 3; then compounds 1 and 2 (each within the scatter of the next); then compound 4.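

In this assay, going by these compounds alone, the step from 4-nitrophenyl to isopentyl on an oxygen next to a carbonyl group, which gives a 4.3-fold higher number from compound 2 to compound 4 (0.64 log units; beyond the scatter), is the first change at this end of the carbamate to remove the aromatic ring, and it shows that an open chain is not tolerated as a neutral swap on the core of compound 2. The earlier change here kept the ring and altered only its substituent, with a 3.0-fold lower number from compound 1 to compound 3 (0.48 log units; beyond the scatter), so the compound carrying 4-nitrophenyl now has the lower number in both steps at this end, and neither step goes against that within these four compounds. No measurement given here accounts for the rise on leaving the aromatic ester.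

From the compounds shown here alone, it remains open whether the ring itself or its nitro group matters more, which a benzyl group or an unsubstituted phenyl would help to separate, and whether a shorter or longer chain would behave as isopentyl does. Also open, going by these compounds, is whether isopentyl on the core of compound 3 would give a step of similar size to the one seen on the core of compound 2.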